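Ester and halogen changes at a dipeptidyl peptidase 9 limit

A few compounds are considered here, and "the series" means these few. Any claim that something is new, unique, unknown or untested is made for them only; others in the source may bear on it.

Compound 3 `CC#CCn1c(N2CCC[C@@H](N)C2)nc2c1c(=O)n(Cc1cc(Cl)ccc1C(=O)O)c(=O)n2C` was tested in an ADME assay on isolated protein for inhibition of Dipeptidyl peptidase 9 (Homo sapiens), with stated times of 15 min, 60 s and 20 min; on this read-out lower numbers stand for stronger inhibition and higher numbers for weaker inhibition. In this assay compound 3 gives > 100000 nM, which is a limit of the assay and not a number. Compound 1 `CC#CCn1c(N2CCC[C@@H](N)C2)nc2c1c(=O)n(Cc1ccc(Br)cc1C(=O)OC)c(=O)n2C` gives > 100000 nM, again only a limit. Compound 2 `CC#CCn1c(N2CCC[C@@H](N)C2)nc2c1c(=O)n(Cc1cccc(F)c1C(=O)O)c(=O)n2C` gives > 100000 nM, also a limit. The steps among them, a step that the two limits leave unreadable from compound 1 to compound 2, a step that the two limits leave unreadable from compound 1 to compound 3 and a step that the two limits leave unreadable from compound 2 to compound 3, cannot be sized because every value sits at the limit of > 100000 nM in this assay, at which 3 of the 3 values shown sit. The change to compound 4 `CC#CCn1c(N2CCC[C@@H](N)C2)nc2c1c(=O)n(Cc1cccc(F)c1C(=O)OC)c(=O)n2C` is 3-fluoro-2-(methoxycarbonyl)phenyl in place of 2-carboxy-5-chlorophenyl on a saturated chain carbon bound to an aromatic nitrogen. Among the measured compounds shown here, it joins the methoxycarbonyl of compound 1 to the fluorine of compound 2, and no measured step points to any shift. Compound 4 is therefore expected near 150000 nM, within 50000 nM to 500000 nM. That estimate means a step that the limit leaves unreadable from compound 3 to compound 4, and most likely the assay again reports only its limit.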

Compound 4, half-maximal inhibitory concentration: > 100000 nM
Compound 4: a limit, no number; the forecaster's own chance of this, stated with the estimate: 85%; the middle value lies beyond the limit too.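

Compound 4 gives only a limit, so none of its steps to compound 1, compound 2 or compound 3 can be read, because every value stands at the same limit: the limit of > 100000 nM in this assay, at which 4 of the 4 values shown sit.

The compounds shown leave open whether any of these ester or halogen changes alters inhibition at all.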